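Saturating One Double Bond in a Long Side Chain

A few compounds are considered here, and "the series" means these few. Any claim that something is new, unique, unknown or untested is made for them only; others in the source may bear on it.

Measured so far:
compound 1 `CCCC/C=C\CCCCCCCCCc1cc(=O)c2c(O)cc(O)c(C)c2o1` gives 6790 nM in a functional assay on MDA-MB-231 cells (Homo sapiens) for antiproliferative activity, read by MTT assay; a higher number here means a weaker inhibitor, a lower number a stronger inhibitor
compound 2 `CCCCC/C=C\C/C=C\CCCCCCCc1cc(=O)c2c(O)c(C)c(O)c(C)c2o1` gives 16100 nM
compound 3 `CC/C=C\C/C=C\C/C=C\CCCCCCCc1cc(=O)c2c(O)cc(O)c(C)c2o1` gives 6790 nM

Compound 3 stands level with compound 1 at the digits shown, the two together the lowest of the three numbers, while compound 2 stands higher by a gap beyond the scatter. Compound 4 `CCCCC/C=C\C/C=C\CCCCCCCc1cc(=O)c2c(O)cc(O)c(C)c2o1` differs from compound 3 by butyl in place of but-1-en-1-yl on a saturated chain carbon bound to a double-bonded chain carbon. Within the data shown here, the one step that bears on this is no change at the digits printed from compound 1 to compound 3 (within the scatter), where a chain with three double bonds replaced one with a single double bond and the number did not move. Removing one double bond from the chain of compound 3 is therefore expected to leave the number about where it is, a 1.0-fold higher number from compound 3 to compound 4 (0.01 log units; within the scatter). Compound 4 is estimated at 7000 nM, between 3500 nM and 14000 nM.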

Compound 4, half-maximal inhibitory concentration: 6790 nM
Compound 4: the middle estimate sits 1.0-fold (0.01 log units) above what was measured, and the stated range covers the measured number.
By their numbers in this assay, from the lowest: compounds 1, 3 and 4 (each within the scatter of the next); then compound 2.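

In this assay, removing one double bond gives no change at the digits printed from compound 3 to compound 4 (within the scatter), and the change of chain between the other two compounds gives no change at the digits printed from compound 1 to compound 4 (within the scatter), so these chains show no difference in this assay. The methyl on the aromatic carbon tells a different story: hydrogen in its place, with the chain held the same, gives a 2.4-fold lower number from compound 2 to compound 4 (0.37 log units; beyond the scatter). Among these compounds, this is the first single-place change here to go beyond the scatter.

Nothing available explains either result. Going by these compounds, whether a much shorter chain, or a carboxylic acid at the chain's end, would move the number remains open.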